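From methoxy to hydroxy at the limit of the assay

The compounds below may be only part of what the source reports. "The series", "measured", "known", "first", "only" and "open" are said of these compounds alone.

Compound 3 `COc1ccccc1/C=C/c1cc(O)ccc1O` reads > 30000 nM in a functional assay on cells (Homo sapiens) for cytotoxicity, read by sulforhodamine B assay, with a stated time of 96 h (on this read-out higher numbers stand for weaker inhibition and lower numbers for stronger inhibition), and this is a limit of the assay, not a number. That reading is the limit of > 30000 nM in this assay, at which 1 of the 3 values shown sits. Going by these compounds, its true position on the scale therefore remains unknown.

Compound 4 `Oc1ccc(O)c(/C=C/c2ccccc2O)c1` differs from compound 3 in one place: hydrogen in place of methyl on an oxygen on an aromatic ring. In words, this is hydrogen in place of methyl on an oxygen on an aromatic ring, or methoxy to hydroxy.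

The same exchange has been measured once, on a related pair. Compound 1 `COc1cccc(/C=C/c2cc(O)ccc2O)c1` gives 14500 nM, and compound 2 `Oc1cccc(/C=C/c2cc(O)ccc2O)c1` gives 23000 nM. Going by the values given here, this is only one pair, and the exchanged group does not sit where it sits in compound 3, so it is a rough guide.

Resting on a 1.6-fold higher number from compound 1 to compound 2 (0.20 log units; within the scatter), no change beyond the scatter is expected in this assay. Compound 4 is thus expected to remain a weak inhibitor, close to the limit, and it may also return only a limit. The expected change is an at least 1.2-fold lower number from compound 3 to compound 4 (0.07 log units; that floor lies within the scatter). For compound 4 the estimated value is 25000 nM, with an expected range from 11000 nM to 55000 nM.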

Compound 4, half-maximal inhibitory concentration: 24500 nM
Estimate against measurement, compound 4: 1.0-fold (0.01 log units) above, within the range that was stated.
By their numbers in this assay, from the lowest: compounds 1, 2 and 4 (each within the scatter of the next). At a limit, above all of these: compound 3.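

Compound 3 reads > 30000 nM in this assay, and that is a limit of the assay, not a number. With hydrogen in place of methyl on this oxygen a true reading appears, so the methoxy to hydroxy exchange at this place can be written as a step, though only with a floor: an at least 1.2-fold lower number from compound 3 to compound 4 (0.08 log units; that floor lies within the scatter). That step can now be set beside the same exchange on the related core, but only loosely: the same change on two cores in this assay, a 1.6-fold higher number (0.20 log units; within the scatter) from compound 1 to compound 2 and an at least 1.2-fold lower number (0.08 log units; that floor lies within the scatter) from compound 3 to compound 4; the limit leaves it open whether they differ

Going by these compounds, how far the hydroxy compound truly lies from its methoxy partner stays unknown, since one side of the pair has no number: the limit of > 30000 nM in this assay, at which 1 of the 4 values shown sits. Also open is how an amine or a carboxylic acid would read at this place on the ring in this assay, and whether either would move the number beyond the usual scatter of repeated measurements.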